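The compounds below may be only part of what the source reports. "The series", "measured", "known", "first", "only" and "open" are said of these compounds alone.

Within the data shown here, compound 1 `CC(O)(C(=O)Nc1ccc(S(=O)(=O)c2ccccc2O)cc1)C(F)(F)F` is the higher of the two numbers known so far in a functional assay (Cavia porcellus) with sulfonylurea receptors; K-ATP channels (Homo sapiens) as the target (a higher number here means a weaker inhibitor, a lower number a stronger inhibitor), where compound 1 gives 3090 nM. Compound 2 `CC(O)(C(=O)Nc1ccc(S(=O)(=O)c2ccncc2)c(O)c1)C(F)(F)F` stands closer to the lower end, and in this assay compound 2 gives 1300 nM. Compound 3 `CC(O)(C(=O)Nc1ccc(S(=O)(=O)c2cnccn2)cc1)C(F)(F)F` has not yet been measured; it differs from compound 1 in one place, (pyrazin-2-yl in place of 2-hydroxyphenyl on a sulfonyl sulfur). Among the measured compounds shown here, no measured pair shows exactly this change, so the step is expected to be small and within the usual scatter, here written as a 1.2-fold lower number from compound 1 to compound 3 (0.09 log units; within the scatter). For compound 3 the estimate in this assay is 2500 nM, with a range from 800 nM to 8000 nM.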

Compound 3, half-maximal inhibitory concentration: 12000 nM
The estimate for compound 3 lay 4.8-fold (0.68 log units) below the measured number; measured number outside the range, above it.
By their numbers in this assay, from the lowest: compound 2; then compound 1; then compound 3.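

In this assay, the group on the sulfonyl sulfur proves to matter: pyrazin-2-yl in place of 2-hydroxyphenyl gives a 3.9-fold higher number from compound 1 to compound 3 (0.59 log units; beyond the scatter), a weakening of inhibition beyond the scatter. The exchange removes the hydrogen-bond donor of 2-hydroxyphenyl and brings in a ring with 2 hetero atoms, but nothing available ties the step to either difference. Still open, going by these compounds, is whether a plain phenyl group would stand nearer compound 1 or compound 3, and whether an amine or a carboxylic acid on that ring would restore inhibition.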